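Replacing a large ester with methyl in a cytotoxicity test

A few compounds are considered here, and "the series" means these few. Any claim that something is new, unique, unknown or untested is made for them only; others in the source may bear on it.

Compound 1 `COc1cc(C2Oc3cc(-c4oc5cc(O)cc(O)c5c(=O)c4OC)ccc3OC2CO)ccc1O` gives 22500 nM
Compound 2 `COc1cc(C2Oc3cc(-c4oc5cc(O)cc(O)c5c(=O)c4O)ccc3OC2COC(=O)c2cc(O)c(O)c(O)c2)ccc1O` gives 11500 nM

In an ADME assay on HUVEC cells (Homo sapiens) for cytotoxicity, read by MTT assay, with a stated time of 24 h (a higher number here means a weaker inhibitor, a lower number a stronger inhibitor), compound 2 gives 11500 nM and compound 1 gives 22500 nM so the two lie within the usual scatter of each other, and neither can be ranked above the other. Compound 3 `COCC1Oc2ccc(-c3oc4cc(O)cc(O)c4c(=O)c3O)cc2OC1c1ccc(O)c(OC)c1` has not yet been measured. Going from compound 2 to compound 3, the change is methyl in place of (3,4,5-trihydroxyphenyl)carbonyl on an oxygen on a saturated carbon in short, methyl in place of (3,4,5-trihydroxyphenyl)carbonyl on an oxygen on a saturated carbon. Within the data shown here, no measured pair isolates this change, so the expectation is loose. In this assay no step beyond the scatter is expected, with a slight lean towards a higher number. The estimated step is a 1.6-fold higher number from compound 2 to compound 3 (0.19 log units; within the scatter) and it remains uncertain. Compound 3 is estimated at 18000 nM with an expected range from 7000 nM to 45000 nM for its measurement.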

Compound 3, half-maximal inhibitory concentration: 28300 nM
Estimate against measurement, compound 3: 1.6-fold (0.20 log units) below; measured number inside the range.
By their numbers in this assay, from the lowest: compounds 2, 1 and 3 (each within the scatter of the next, the first and the last beyond it).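

In this assay, the swap gives a 2.5-fold higher number from compound 2 to compound 3 (0.39 log units; beyond the scatter) and so counts as a modest real change, with the larger group on the lower number. Compounds 1 and 2 differ in more than one place and could not show this, whereas here the only difference is methyl in place of (3,4,5-trihydroxyphenyl)carbonyl on an oxygen on a saturated carbon. The departing group carries an aromatic ring, a carbonyl and hydrogen-bond donors, and no measurement available here shows which of these parts matters or why the number moves.

From the compounds shown here alone, whether a small acetyl or an unsubstituted benzoyl on this oxygen would fall nearer compound 2 or compound 3 stays open. So does the effect of an amine at this place.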